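The source may hold more compounds than are shown below. What is called first, only, known or untested is meant among the compounds shown, and "the series" means these compounds.

Working notes on the series: in an ADME assay on microsomes from liver (Homo sapiens) for metabolic stability (a higher number here means that the compound lasts longer, a lower number that the compound disappears faster), compound 2 (`CCS(=O)(=O)c1ccc(CNC(=O)c2ccc3c(c2)cc(Cc2ccccc2Br)n3C(C)C)cc1`) gives 0.25 h and holds the lower of the two numbers so far. Compound 1 (`CCS(=O)(=O)c1ccc(CNC(=O)c2ccc3c(c2)cc(Cc2ccc(Cl)cc2C(F)(F)F)n3C2CC2)cc1`) gives 2.32 h in this assay and lies above compound 2 by a gap beyond the scatter. These two compounds differ in more than one place, so that gap cannot be assigned to any single change.

Compound 3 (`CCS(=O)(=O)c1ccc(CNC(=O)c2ccc3c(c2)cc(Cc2ccccc2C(F)(F)F)n3C(C)C)cc1`) departs from compound 2 at one place only, with trifluoromethyl in place of bromo on an aromatic carbon, ortho to a large group (trifluoromethyl in place of bromo on an aromatic carbon) as the whole difference. Among the compounds with values here, no measured pair shows this change, so its size has no direct precedent here.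

A small rise in half-life is expected, perhaps not clearly beyond the scatter, and the estimated move is a 1.8-fold higher number from compound 2 to compound 3 (0.26 log units; within the scatter) in this direction. The upward lean is weak, resting only on the higher number of compound 1 at 2.32 h as measured so far. For compound 3 the estimated half-life is 0.45 h within an expected range of 0.17 h to 1.3 h in this assay when measured.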

Compound 3, half-life: 0.65 h
Estimate against measurement, compound 3: 1.4-fold (0.16 log units) below; the measured number falls inside the stated range.
By their numbers in this assay, from the lowest: compound 2; then compound 3; then compound 1.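

In this assay, within the data shown here, the step from bromo to trifluoromethyl on an aromatic carbon, ortho to a large group, is a 2.6-fold higher number from compound 2 to compound 3 (0.41 log units; beyond the scatter), and it is the first difference that can be assigned to one place. It shows that half-life responds to the group at this position, and that the 2-bromobenzyl to 2-(trifluoromethyl)benzyl exchange moves it upward by a modest amount, on the background shared by compound 2 and compound 3 only. The compounds shown offer no measured basis for a reason behind this step.

From the compounds shown here alone, whether the same exchange gives a step of similar size and direction on the background of compound 1, which differs from compound 3 in more than one place, remains open, and the gap between those two compounds stays unassigned. Among these compounds, also open is how half-life would respond to a methoxy group, a nitrile, an amine or a carboxylic acid at this position, since two groups give only one step and no trend across substituents.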